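From Phenyl to 3-Nitrophenyl: Estimating Compound 3

The compounds below may be only part of what the source reports. "The series", "measured", "known", "first", "only" and "open" are said of these compounds alone.

Measured compounds:
compound 1, `CC(C)=CCC/C(C)=C/CC/C(C)=C/CC[C@@H]1[C@@]2(C)CC/C(=N\OCc3cn(-c4ccccc4)nn3)C(C)(C)[C@@H]2CC[C@@]1(C)O`, 8830 nM
compound 2, `CC(C)=CCC/C(C)=C/CC/C(C)=C/CC[C@@H]1[C@@]2(C)CC/C(=N\OCc3cn(-c4cccc(Br)c4)nn3)C(C)(C)[C@@H]2CC[C@@]1(C)O`, 14600 nM

Among the compounds with values here, in a functional assay on DU-145 cells (Homo sapiens) for cytotoxicity, read by MTT assay, with a stated time of 48 h (a lower number here means a stronger inhibitor, a higher number a weaker inhibitor), compound 1 gives 8830 nM, the lowest of the two numbers known. Compound 2 gives 14600 nM, and the step of a 1.7-fold higher number from compound 1 to compound 2 (0.22 log units; within the scatter) shows that bromo in place of hydrogen on an aromatic carbon left the result within the scatter.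

Compound 3, `CC(C)=CCC/C(C)=C/CC/C(C)=C/CC[C@@H]1[C@@]2(C)CC/C(=N\OCc3cn(-c4cccc([N+](=O)[O-])c4)nn3)C(C)(C)[C@@H]2CC[C@@]1(C)O`, has not yet been tested. It differs from compound 1 by nitro in place of hydrogen on an aromatic carbon. Within the data shown here, the only measured step that bears on this change is the one from compound 1 to compound 2, where another group entered the same kind of position and the number barely moved. Compound 3 is therefore expected to sit close to compound 1, with a step of a 1.4-fold higher number from compound 1 to compound 3 (0.13 log units; within the scatter) that stays within the scatter. The estimate for compound 3 in this assay is 12000 nM, with a range from 5000 nM to 30000 nM.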

Compound 3, half-maximal inhibitory concentration: 17400 nM
Compound 3: middle estimate off by 1.5-fold (0.16 log units), on the low side; measured number inside the range.
By their numbers in this assay, from the lowest: compounds 1, 2 and 3 (each within the scatter of the next).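

Nitro in this place gives a 2.0-fold higher number from compound 1 to compound 3 (0.29 log units; within the scatter) in this assay, so two different groups, bromo and the three-heavy-atom nitro, have now replaced the hydrogen on this aromatic carbon without a step beyond the scatter. Exchanging one group for the other gives a 1.2-fold higher number from compound 2 to compound 3 (0.08 log units; within the scatter), so this assay does not tell compounds with these two groups apart. No measurement shown here gives a reason for these small steps.

The compounds shown leave open whether an amine, a carboxylic acid or a longer chain in the same place would also stay within the scatter of compound 1. They also leave open whether nitro or bromo on a different carbon of the six-membered aromatic ring would give a similar result.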